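The source may hold more compounds than are shown below. What is called first, only, known or untested is meant among the compounds shown, and "the series" means these compounds.

Working notes on the series.

Two compounds have been run in a functional assay on the whole organism (Tail, strain ICR) with Mus musculus as the target, in the tail flick test, with a stated time of 120 min, at a dose of 25 umol/kg by the oral route; a lower number here means a weaker effect, a higher number a stronger effect of the compound at the dose given. Compound 1, `O=C(O)[C@@H]1CCCN1C(=O)CN(c1nc(Cl)nc2[nH]cnc12)C1CC1`, carries a carboxylic acid on its proline part and a chlorine on the shared core; in this assay compound 1 gives 23.6%. Compound 2, `CC[C@H](C)[C@H](NC(=O)CN(c1ncnc2c1ncn2C1CCCCO1)C1CC1)C(=O)OCc1ccccc1`, carries instead a benzyl ester on an isoleucine part and a tetrahydropyranyl on the core; in this assay compound 2 gives 20.4%. Going by the values given here, the two values lie within the usual scatter of each other, so no order between compound 1 and compound 2 can be read from them, and no step between them is set out.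

Compound 3, `C[C@@H](O)[C@H](NC(=O)CN(c1ncnc2c1ncn2C1CCCCO1)C1CC1)C(=O)OCc1ccccc1`, has not been measured. It differs from compound 2 in one place: hydroxy in place of ethyl on a saturated chain carbon bound to two saturated chain carbons. Among the compounds with values here, no measured pair shows such a change, so there is nothing to anchor its size; the expectation is a step of no size beyond the scatter, in either direction, as a number 0.4 percentage points lower from compound 2 to compound 3 (within the scatter). Compound 3 is accordingly expected to give about 20% in this assay, with a range from 7% to 35%.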

Compound 3, a percentage reported as activity, at one dose (the size of the read-out at that dose, not a potency): 10.9%
Beside the measured number, compound 3's estimate is 9.1 percentage points above it; low and high end bracket the measured number.
By their numbers in this assay, from the lowest: compounds 3, 2 and 1 (each within the scatter of the next, the first and the last beyond it).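

Going by these compounds alone, the first step that can be read is a number 9.5 percentage points lower from compound 2 to compound 3 (within the scatter) in this assay, for hydroxy in place of ethyl on a saturated chain carbon bound to two saturated chain carbons, the difference that also reads sec-butyl to 1-hydroxyethyl. As this step lies within the usual scatter, the compounds show no effect at this place that can be told apart from repeated measurement at the single dose and time given, even though the exchange brings in a hydrogen-bond donor and a hydrogen-bond acceptor that the ethyl lacks. No data are at hand that could explain the size of this step.

On these data alone, it remains open whether an amine, a carboxylic acid or a longer chain such as n-hexyl on this same saturated chain carbon would give a step beyond the scatter. Also open, as far as these compounds go, is whether hydroxy in place of ethyl would give a step of similar size on a compound with a free carboxylic acid instead of the benzyl ester.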